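Amine ring size and amide alkylation in a chlorophenyl series

The source may hold more compounds than are shown below. What is called first, only, known or untested is meant among the compounds shown, and "the series" means these compounds.

Compound 1 `O=C(CC(CC(=O)NC1Cc2ccccc2C1)c1ccc(Cl)cc1)NCCN1CCCCC1` carries an unsubstituted amide nitrogen and a chain ending in a piperidine. In a functional assay on MCF7 cells (Homo sapiens) for inhibition (on this read-out lower numbers stand for stronger inhibition and higher numbers for weaker inhibition), compound 1 gives 35500 nM. Compound 2 `O=C(CC(CC(=O)NC1Cc2ccccc2C1)c1ccc(Cl)cc1)NCCN1CCCC1` differs from compound 1 by pyrrolidin-1-yl in place of piperidin-1-yl on a saturated chain carbon, two bonds along the chain from an amide-type nitrogen. For compound 2 this assay reports only a limit, > 100000 nM. The step of an at least 2.8-fold higher number from compound 1 to compound 2 (0.44 log units; beyond the scatter) is thus bounded on one side only, the bound being (the limit of > 100000 nM in this assay, at which 1 of the 3 values shown sits).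

Compound 3 `CCN(C(=O)CC(CC(=O)NCCN1CCCCC1)c1ccc(Cl)cc1)C1Cc2ccccc2C1` differs from compound 1 in the core by ethyl in place of hydrogen on an amide-type nitrogen. In this assay compound 3 gives 16500 nM, and the step of a 2.2-fold lower number from compound 1 to compound 3 (0.33 log units; beyond the scatter) lies beyond the scatter, so compound 3 holds the lowest of the two numbers available.

Compound 4 `CCN(C(=O)CC(CC(=O)NCCN1CCCC1)c1ccc(Cl)cc1)C1Cc2ccccc2C1` is not yet measured. It stands to compound 3 as compound 2 stands to compound 1: the change is pyrrolidin-1-yl in place of piperidin-1-yl on a saturated chain carbon, two bonds along the chain from an amide-type nitrogen, the same change at the same place as between compound 1 and compound 2. Among the measured compounds shown here, the only measured instance of this change is an at least 2.8-fold higher number from compound 1 to compound 2 (0.44 log units; beyond the scatter), which is itself only a bound. Carrying that same bound forward, the step from compound 3 to compound 4 is expected to be a 3.6-fold higher number from compound 3 to compound 4 (0.56 log units; beyond the scatter). Compound 4 is accordingly expected to give about 60000 nM in this assay, within a range from 25000 nM to 150000 nM. Because the earlier instance ended at the limit of > 100000 nM in this assay, at which 1 of the 3 values shown sits, a second limit rather than a number is a real possibility for compound 4.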

Compound 4, half-maximal inhibitory concentration: 20400 nM
Beside the measured number, compound 4's estimate is 2.9-fold (0.47 log units) above it; the whole stated range lies above it.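

In this assay, pyrrolidin-1-yl in place of piperidin-1-yl on the core of compound 3 gives a 1.2-fold higher number from compound 3 to compound 4 (0.09 log units; within the scatter), so on this ethyl-bearing core the ring change leaves no readable shift. This does not establish that the change carries differently from one core to the other, nor that it carries unchanged, since compound 2 is recorded only as a limit and its step gives a bound rather than a size: the same change on two cores in this assay, an at least 2.8-fold higher number (0.44 log units; beyond the scatter) from compound 1 to compound 2 and a 1.2-fold higher number (0.09 log units; within the scatter) from compound 3 to compound 4; the limit leaves it open whether they differ

Ethyl in place of hydrogen on the amide-type nitrogen, read with the pyrrolidin-1-yl chain, gives an at least 4.9-fold lower number from compound 2 to compound 4 (0.69 log units; beyond the scatter), which runs in the same direction as the step with the piperidin-1-yl chain, though whether the two steps differ in size stays unsettled: the same change on two cores in this assay, a 2.2-fold lower number (0.33 log units; beyond the scatter) from compound 1 to compound 3 and an at least 4.9-fold lower number (0.69 log units; beyond the scatter) from compound 2 to compound 4; the limit leaves it open whether they differ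

Open, on these data alone, is whether other amines at the end of the chain, such as morpholine or dimethylamine, or a longer chain than 2-(piperidin-1-yl)ethyl, would follow the same course on either core. Also open, as far as these compounds go, is how a methyl or propyl group on the amide-type nitrogen would compare with ethyl, and whether the ring-size result would hold with it.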